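A Hydroxy Group in Place of the Difluorobenzyl Arm

The source may report more compounds than this note shows. Statements on the series, on what has been measured and on what is new or still open speak of the compounds shown alone.

Three amides on one shared core have been tested in a functional assay on CHO-K1 cells for antagonist activity at transient receptor potential cation channel subfamily V member 1 (Homo sapiens), read by FLIPR; a lower number here means a stronger inhibitor, a higher number a weaker inhibitor. Compound 1 `CC(C(=O)NCc1ccc(C(F)(F)F)nc1NCc1ccc(Cl)cc1)c1ccc(NS(C)(=O)=O)c(F)c1` gives 414 nM, compound 2 `CCCCN(C)c1nc(C(F)(F)F)ccc1CNC(=O)C(C)c1ccc(NS(C)(=O)=O)c(F)c1` gives 21.3 nM, and compound 3 `CC(C(=O)NCc1ccc(C(F)(F)F)nc1N1CCC(Cc2cc(F)cc(F)c2)CC1)c1ccc(NS(C)(=O)=O)c(F)c1` gives 24 nM. Compound 3 thus stands second highest of the three; its number and that of compound 2 lie within the scatter of each other, while compound 1 sits far above both. Compound 4 `CC(C(=O)NCc1ccc(C(F)(F)F)nc1N1CCC(O)CC1)c1ccc(NS(C)(=O)=O)c(F)c1` differs from compound 3 in one place: hydroxy in place of 3,5-difluorobenzyl on a saturated ring carbon. Going by the values given here, the only measured step, a 19-fold lower number from compound 1 to compound 2 (1.29 log units; beyond the scatter), also removed a benzyl-type group and the number fell sharply, so it is no direct guide for this assay here. Compound 4 is expected to give a somewhat higher number, estimated at 90 nM (range 25 nM to 400 nM), a step of a 3.8-fold higher number from compound 3 to compound 4 (0.57 log units; beyond the scatter) just beyond the scatter.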

Compound 4, half-maximal inhibitory concentration: "not active" (no number reported)
No number was reported for compound 4; no gap can be computed for the estimate.
By their numbers in this assay, from the lowest: compounds 2 and 3 (each within the scatter of the next); then compound 1.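

Going by these compounds alone, compound 4 was reported as not active in this assay, with no number, so no step from compound 3 to compound 4 can be read. The compounds shown leave open how other groups at that saturated ring carbon would read out. Nothing shown accounts for this result.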